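Halogen swap on the aryl ring of the rhodanine series

The source may hold more compounds than are shown below. What is called first, only, known or untested is meant among the compounds shown, and "the series" means these compounds.

All numbers come from a functional assay on HEp-2 cells (Homo sapiens) for cytotoxicity, read by MTT assay, with a stated time of 72 h, tested at 1.25 ug/mL; a higher number here means more inhibition of growth at the concentration tested, a lower number less inhibition of growth.

- compound 1 `O=C1NC(=S)/C(=C/c2ccc(Cl)cc2)S1` gives 0.92%
- compound 2 `O=C1NC(=S)/C(=C/c2ccccc2Br)S1` gives 3.14%
- compound 3 `O=C1NC(=S)/C(=C/c2ccccc2Cl)S1` gives -11.3%

Compound 3 stands lowest of the three numbers; compound 1 lies higher by a margin beyond the scatter, and compound 2 lies furthest, also beyond the scatter. For the measured compounds named here, only one measured pair differs in a single place, and it concerns the same carbon: a number 14.4 percentage points lower from compound 2 to compound 3 (beyond the scatter), a modest step. Compound 4 `O=C1NC(=S)/C(=C/c2ccccc2F)S1` differs from compound 3 by fluoro in place of chloro on an aromatic carbon. Going by the values given here, the set holds nothing on fluoro, so the one halogen-for-halogen step is the only guide; it was modest, and the step to compound 4 is expected to be of similar or smaller size in this assay, with no firm direction. Compound 4 is therefore estimated at -3%, within a range from -18% to 12%. The step this estimate implies, a number 8.3 percentage points higher from compound 3 to compound 4 (within the scatter), is expected to stay inside the scatter.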

Compound 4, percent growth inhibition at one concentration: -8.34%
Compound 4: the middle estimate sits 5.3 percentage points above what was measured; measured number inside the range.
By their numbers in this assay, from the lowest: compounds 3, 4, 1 and 2 (each within the scatter of the next, the first and the last beyond it).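

In this assay, fluoro in place of chloro on an aromatic carbon gives a number 3 percentage points higher from compound 3 to compound 4 (within the scatter), so these two halogens are not separated at this position. Fluoro in place of bromo gives a number 11.5 percentage points lower from compound 2 to compound 4 (beyond the scatter), which means that bromo now stands apart from both fluoro and chloro at this position, rather than from chloro alone. Nothing available gives a reason for this separation of bromo.

On these data alone, it remains open whether a non-halogen group at this position, such as an amine, a methoxy group or a carboxylic acid, would move the number further than these halogen swaps do. The compounds also leave open whether the same separation of bromo would appear at other concentrations or with the halogen elsewhere on the aromatic ring.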